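Trifluoromethoxy for trifluoromethyl on compound 3

The source may hold more compounds than are shown below. What is called first, only, known or untested is meant among the compounds shown, and "the series" means these compounds.

- compound 1 `FC(F)(F)c1ccccc1-c1ccc2[nH]c(C3=NCC4(CCCCC4)O3)nc2c1` gives 73% remaining
- compound 2 `FC(F)(F)c1ccccc1-c1ccc2[nH]c(C3=NC4(CCCCC4)CO3)nc2c1` gives 85% remaining
- compound 3 `FC(F)(F)c1ccccc1-c1ccc2[nH]c(C3=NOC4(CCCCC4)C3)nc2c1` gives 100% remaining

In an ADME assay on microsomes from liver (Homo sapiens) for metabolic stability, with a stated time of 10 min (a higher number here means that more of the compound is left, a lower number that less of the compound is left), compound 3 stands highest of the three with 100% remaining, beyond the scatter of both compound 2 and compound 1. Compound 4 `FC(F)(F)Oc1ccccc1-c1ccc2[nH]c(C3=NOC4(CCCCC4)C3)nc2c1` has trifluoromethoxy in place of trifluoromethyl on an aromatic carbon, ortho to a large group (trifluoromethoxy in place of trifluoromethyl on an aromatic carbon). Going by the values given here, no measured pair shows this change, so the expectation rests on compound 3 alone, at 100% remaining. Expected in this assay is a number 8 percentage points lower from compound 3 to compound 4 (within the scatter) and thus no step beyond the scatter. For compound 4 the expected value is 92% within a range of 78% to 100% as estimated.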

Compound 4, percent of the compound remaining: 100%
Compound 4: the middle estimate sits 8 percentage points below what was measured; low and high end bracket the measured number.
By their numbers in this assay, from the lowest: compound 1; then compound 2; then compounds 3 and 4 (each within the scatter of the next).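

In this assay, going by these compounds alone, trifluoromethoxy in place of trifluoromethyl on an aromatic carbon, ortho to a large group, gives no change at the digits printed from compound 3 to compound 4 (within the scatter), the first reading of a change in one place. This position therefore tolerates the change without a step beyond the scatter, although compound 4 at 100% leaves no room for a gain to appear. Nothing measured here explains the result.

On these data alone, whether an amine or a nitrile at this position would keep this stability remains open. Also open, as far as these compounds go, is whether the same change would give a similar result on compound 1, whose number leaves more room for a gain.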